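This account rests on a few compounds, and the source may have more. Where it says the series, first, only, none or still open, it means among the compounds named here.

Compound 3 `CC(/C=N/Nc1ccc([N+](=O)[O-])cc1)=N\NC(=O)c1ccc([N+](=O)[O-])cc1` is one of three measured members of a small set tested in an ADME assay on J774 cells (Mus musculus, strain BALB/c) for cytotoxicity, read by resazurin assay, with a stated time of 72 h; on this read-out higher numbers stand for lower toxicity in this test and lower numbers for higher toxicity in this test. In this assay compound 3 gives > 100000 nM, a limit of the assay rather than a number. Compound 2 `COc1ccc(C(=O)N/N=C(C)/C=N/Nc2ccc([N+](=O)[O-])cc2)cc1` reaches the same limit in this assay, giving > 100000 nM. The step from compound 2 to compound 3 (a step that the two limits leave unreadable from compound 2 to compound 3) therefore cannot be sized, since both values sit at the limit of > 100000 nM in this assay, at which 2 of the 3 values shown sit. Compound 1 `CC(/C=N/N(C)c1ccc([N+](=O)[O-])cc1)=N\NC(=O)c1ccc(N)cc1` differs from compound 3 in several places. In this assay compound 1 gives 51700 nM, a value that stays within the measured range. Compound 4 `CC(/C=N/Nc1ccc([N+](=O)[O-])cc1)=N\NC(=O)c1ccccc1N` is the next member, not yet measured. It differs from compound 3 by 2-aminophenyl in place of 4-nitrophenyl on a carbonyl carbon. Within the data shown here, no measured step touches this change, and compound 3 itself offers only a limit, so the size and direction of the step are open. The expected value for compound 4 in this assay is 80000 nM, with a range from 35000 nM to 180000 nM, which would mean an estimated step of an at least 1.2-fold lower number from compound 3 to compound 4 (0.09 log units; that floor lies within the scatter).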

Compound 4, half-maximal cytotoxic concentration: 29800 nM
Estimate against measurement, compound 4: 2.7-fold (0.43 log units) above; the whole stated range lies above it.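

In this assay, putting 2-aminophenyl in place of 4-nitrophenyl on the carbonyl carbon gives an at least 3.3-fold lower number from compound 3 to compound 4 (0.52 log units; beyond the scatter) and putting it in place of 4-methoxyphenyl gives an at least 3.3-fold lower number from compound 2 to compound 4 (0.52 log units; beyond the scatter), so the group at this place can shift the read-out toward higher toxicity in this test. The earlier compounds shown here could not show this, as the step between the two compounds at the limit cannot be read. Both new steps give only a minimum size, not a full one, because compound 2 and compound 3 each stand at a limit and not at a number: the limit of > 100000 nM in this assay, at which 2 of the 4 values shown sit.

As far as these compounds go, whether the shift belongs to the amino group itself or to the loss of the nitro and methoxy groups stays open. An unsubstituted phenyl or a carboxylic acid on this ring could help separate the two.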